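Carbamoyl to carboxymethyl on the side chain of compound 3

The source may report more compounds than this note shows. Statements on the series, on what has been measured and on what is new or still open speak of the compounds shown alone.

Measured in a functional assay on CCRF-CEM cells (Homo sapiens) for antiproliferative activity; on this read-out lower numbers stand for higher toxicity in this test and higher numbers for lower toxicity in this test
- Compound 1 `Cc1cn(C2OC(CO[Si](C)(C)C(C)(C)C)C3(OS(=O)(=O)C=C3N)C2O[Si](C)(C)C(C)(C)C)c(=O)n(CCCNC(=O)[C@@H]2CCCN2C(=O)[C@@H](N)C(C)C)c1=O` gives 10000 nM
- Compound 2 `Cc1cn(C2OC(CO[Si](C)(C)C(C)(C)C)C3(OS(=O)(=O)C=C3N)C2O[Si](C)(C)C(C)(C)C)c(=O)n(CCCNC(=O)[C@@H]2CCCN2C(=O)[C@H](C)N)c1=O` gives 19000 nM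
- Compound 3 `Cc1cn(C2OC(CO[Si](C)(C)C(C)(C)C)C3(OS(=O)(=O)C=C3N)C2O[Si](C)(C)C(C)(C)C)c(=O)n(CCCNC(=O)[C@@H]2CCCN2C(=O)[C@@H](N)CC(N)=O)c1=O` gives 25000 nM

Compound 3 stands at the upper end of these numbers, though the steps up to it differ in size (a 1.3-fold higher number from compound 2 to compound 3 (0.12 log units; within the scatter) and a 2.5-fold higher number from compound 1 to compound 3 (0.40 log units; beyond the scatter)). Compound 4 (`Cc1cn(C2OC(CO[Si](C)(C)C(C)(C)C)C3(OS(=O)(=O)C=C3N)C2O[Si](C)(C)C(C)(C)C)c(=O)n(CCCNC(=O)[C@@H]2CCCN2C(=O)[C@@H](N)CCC(=O)O)c1=O`) differs from compound 3 by one change (carboxymethyl in place of carbamoyl on a saturated chain carbon, two bonds along the chain from an amine nitrogen and a carbonyl carbon), carboxymethyl in place of carbamoyl on a saturated chain carbon, two bonds along the chain from an amine nitrogen and a carbonyl carbon. Earlier changes on this chain were small (a 1.9-fold higher number from compound 1 to compound 2 (0.28 log units; within the scatter)), and only the modest step to compound 3 passed the scatter. No step beyond the scatter is therefore expected (no change at the digits printed from compound 3 to compound 4 (within the scatter)). For compound 4 the estimated value is 25000 nM (expected range 11000 nM to 55000 nM).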

Compound 4, half-maximal cytotoxic concentration: 30000 nM
Estimate against measurement, compound 4: 1.2-fold (0.08 log units) below; the measured number falls inside the stated range.
By their numbers in this assay, from the lowest: compounds 1, 2, 3 and 4 (each within the scatter of the next, the first and the last beyond it).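

In this assay, a free carboxyl end on the side chain reads the same as the carbamoyl end, with a 1.2-fold higher number from compound 3 to compound 4 (0.08 log units; within the scatter), so this change brings no step beyond the scatter. The 2-carboxyethyl side chain also stays within the scatter of the methyl of compound 2, with a 1.6-fold higher number from compound 2 to compound 4 (0.20 log units; within the scatter), and only the comparison with the isopropyl of compound 1 passes it, with a 3.0-fold higher number from compound 1 to compound 4 (0.48 log units; beyond the scatter). Nothing available explains these small differences. As far as these compounds go, whether an amine at the end of this side chain, or a phenyl ring on this carbon, would give a number apart from these remains open.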